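Does a longer chain bring compound 4 within range?

The compounds below may be only part of what the source reports. "The series", "measured", "known", "first", "only" and "open" are said of these compounds alone.

In a functional assay on MGC-803 cells (Homo sapiens) for antiproliferative activity, read by MTT assay, with a stated time of 48 h (on this read-out higher numbers stand for weaker inhibition and lower numbers for stronger inhibition), compound 3 `CCCCCCCCCn1cc(COC[C@@H]2OC[C@H](N)[C@H]2O)nn1` gives > 128000 nM, which is a limit and not a number. Compound 2 `CCCCCCCn1cc(COC[C@@H]2OC[C@H](N)[C@H]2O)nn1` gives > 128000 nM, which is also a limit. This is the limit of > 128000 nM in this assay, at which 2 of the 3 values shown sit.

Compound 4 `CCCCCCCCCCCCn1cc(COC[C@@H]2OC[C@H](N)[C@H]2O)nn1` is compound 3 with a longer chain, and the difference is propyl in place of hydrogen on a saturated chain carbon, nine bonds along the chain from an aromatic nitrogen.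

Going by the values given here, the only measured step of this kind is a step that the two limits leave unreadable from compound 2 to compound 3. It involves a change on the same chain, but it offers no size to carry forward. The better guide is compound 1 `CCCCCCCCCCCCn1cc(COC[C@@H]2OC[C@H](N)[C@@H]2O)nn1`, which carries the long chain that compound 4 gains. Compound 1 gives a true number, 21400 nM. On the strength of compound 1 at 21400 nM, a clear move towards stronger inhibition is expected. Compound 4 could still stop at the limit. The expected change is an at least 5.1-fold lower number from compound 3 to compound 4 (0.70 log units; beyond the scatter). Among the compounds with values here, only one number supports this expectation, so the range is wide. For compound 4 the estimated value is 25000 nM, with an expected range of 8000 nM to 90000 nM.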

Compound 4, half-maximal inhibitory concentration: 115000 nM
Compound 4: middle estimate off by 4.6-fold (0.66 log units), on the low side, outside the stated range (above it).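

In this assay the propyl change, on a saturated chain carbon, nine bonds along the chain from an aromatic nitrogen, reads as an at least 1.1-fold lower number from compound 3 to compound 4 (0.04 log units; that floor lies within the scatter), and the pentyl change, seven bonds along the chain from an aromatic nitrogen, reads as an at least 1.1-fold lower number from compound 2 to compound 4 (0.04 log units; that floor lies within the scatter). Both are floors and not true sizes, so how far the longer chain really moves the number cannot be told, and the source of that uncertainty is this: the limit of > 128000 nM in this assay, at which 2 of the 4 values shown sit. The new value shows that the long chain does not settle the result alone, since the drawing at one saturated ring carbon, S in compound 1 and R in compound 4, goes with a 5.4-fold higher number from compound 1 to compound 4 (0.73 log units; beyond the scatter), a comparison that isolates this single feature: the fact that compounds 1 and 4 differ only in the configuration as drawn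

Going by these compounds alone, whether a longer chain than the one shared by compound 1 and compound 4 would keep the same gap between the two configurations stays open. So does the effect of a phenyl group in place of the chain on the shared core.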